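Adding One Chlorine to a Barely Active Compound

This account rests on a few compounds, and the source may have more. Where it says the series, first, only, none or still open, it means among the compounds named here.

In a functional assay on MDA-MB-231 cells (Homo sapiens) for cytotoxicity, read by MTT assay, with a stated time of 48 h (a higher number here means a weaker inhibitor, a lower number a stronger inhibitor), compound 1 `COC(=O)c1ccc2[nH]cc(C3(c4c[nH]c5ccc(C(=O)OC)cc45)C(=O)Nc4ccccc43)c2c1` reads > 100000 nM, which is a limit of the assay and not a number. A related structure, compound 2 `O=C1Nc2ccccc2C1(c1c[nH]c2ccc(Cl)cc12)c1c[nH]c2ccc(Cl)cc12`, gives 10000 nM in this assay. Compound 3 `COC(=O)c1ccc2[nH]cc(C3(c4c[nH]c5ccc(C(=O)OC)cc45)C(=O)Nc4ccc(Cl)cc43)c2c1` keeps the core of compound 1 and makes one change: chloro in place of hydrogen on an aromatic carbon. For the measured compounds named here, no measured pair shows what this change does, so only a small gain in strength is expected in this assay. The expected step is modest: an at least 1.4-fold lower number from compound 1 to compound 3 (0.15 log units; that floor lies within the scatter). For compound 3 the estimate is 70000 nM, with an expected range of 20000 nM to 200000 nM.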

Compound 3, half-maximal inhibitory concentration: 10000 nM
Estimate against measurement, compound 3: 7.0-fold (0.85 log units) above; the measured number lies below the stated range.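

In this assay, one chloro in place of hydrogen on the six-membered aromatic ring gives an at least 10-fold lower number from compound 1 to compound 3 (1.00 log units; beyond the scatter). This position therefore responds to a single added atom, which brings compound 3 to a readable number. Compound 1 stands at a limit, so the step has a floor and no known full size: the limit of > 100000 nM in this assay, at which 1 of the 3 values shown sits.

Going by these compounds, whether bromo, methoxy or an amine at this place would do the same remains open. So does whether chloro would bring a similar gain at another position on the ring.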